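This account rests on a few compounds, and the source may have more. Where it says the series, first, only, none or still open, it means among the compounds named here.

Compound 1 `COc1ccc(Nc2cccc3c(C)c(C)sc23)cc1OC` gives 100% in a functional assay for inhibition, with a stated time of 2 h, tested at 0.0625 g/L (on this read-out lower numbers stand for less inhibition and higher numbers for more inhibition at the one concentration tested (going by the name of the read-out)), the highest of the two numbers measured, with compound 2 `COc1ccc(Nc2cccc3c(C)c(C)sc23)cc1` nearest at 99.7%. Going by the values given here, the one measured step, a number 0.3 percentage points lower from compound 1 to compound 2 (within the scatter), removes the other methoxy group from the same ring and lies within the scatter. Compound 3 `COc1cccc(Nc2cccc3c(C)c(C)sc23)c1` differs from compound 1 by hydrogen in place of methoxy on an aromatic carbon. Among the compounds with values here, only the step from compound 1 to compound 2 bears on this change, and it was too small to register; the data hold no step removing this particular methoxy group. Compound 3 is therefore expected to give a number close to that of compound 1, with a step of a number 3 percentage points lower from compound 1 to compound 3 (within the scatter) expected in this assay, no larger than the scatter. The estimate for compound 3 in this assay is 97%, within a range of 85% to 100%.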

Compound 3, a percentage reported as inhibition, at one concentration (the size of the read-out at that concentration, not a potency): 68.9%
Compound 3: the middle estimate sits 28.1 percentage points above what was measured; the whole stated range lies above it.
By their numbers in this assay, from the lowest: compound 3; then compounds 2 and 1 (each within the scatter of the next).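

In this assay hydrogen in place of the methoxy group para to a large group gives a number 31.1 percentage points lower from compound 1 to compound 3 (beyond the scatter), whereas the same exchange at the other methoxy group of compound 1 gives a number 0.3 percentage points lower from compound 1 to compound 2 (within the scatter). The two methoxy groups of compound 1 therefore do not count alike, and this place on the ring is the one of the two where the exchange registers beyond the scatter. Nothing available here accounts for the difference between the two places.

As far as these compounds go, whether another group at this place, such as a hydroxyl, an ethoxy or an amine, would keep the number near that of compound 1 remains open. Also open, from the compounds shown here alone, is whether compound 1 and compound 2 would stay level at lower concentrations, since the read-out comes from one concentration only.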